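The source may report more compounds than this note shows. Statements on the series, on what has been measured and on what is new or still open speak of the compounds shown alone.

Three compounds have been put through an ADME assay on 3T3-L1 cells (Mus musculus) for cytotoxicity, read by MTT assay, with a stated time of 48 h; on this read-out lower numbers stand for stronger inhibition and higher numbers for weaker inhibition:

- compound 1 `CC1(C)CC(=O)C(C(=S)SCc2ccccc2)=C(Nc2ccc(Cl)cc2Cl)C1`, reported as "not determined" (no result reported)
- compound 2 `CC(=O)OC[C@H]1O[C@@H](SC(=S)C2=C(Nc3ccc(Cl)cc3Cl)CC(C)(C)CC2=O)[C@H](OC(C)=O)[C@@H](OC(C)=O)[C@@H]1OC(C)=O`, reported as "not determined" (no result reported)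
- compound 3 `CC(=O)OC[C@H]1O[C@@H](SC(=S)C2=C(Nc3ccc(Cl)cc3Cl)CC(C)(C)CC2=O)[C@H](OC(C)=O)[C@@H](OC(C)=O)[C@H]1OC(C)=O`, reported as > 20 ug/mL

Compound 2 therefore stands without a single number in this assay. Of the two other entries, one is only a limit and one has no number at all. For compound 3 the result is a limit of the assay, (the limit of > 20 ug/mL in this assay, at which 1 of the 3 values shown sits), not a measured figure. This matters for compound 2 because of the fact that compounds 2 and 3 differ only in the configuration as drawn, so the two are close relatives in shape.

The step to compound 4 `CC(=O)OC[C@H]1O[C@@H](SC(=S)C2=C(Nc3ccc(Cl)cc3)CC(C)(C)CC2=O)[C@H](OC(C)=O)[C@@H](OC(C)=O)[C@@H]1OC(C)=O` removes a substituent from the aryl amine: hydrogen in place of chloro on an aromatic carbon. Nothing measured here connects a change of this kind to any shift in this assay, so no step beyond the usual scatter is expected in either direction, with the likeliest outcome being a further limit rather than a number.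

On that basis compound 4 is estimated at 25 ug/mL in this assay, within a range of 8 ug/mL to 80 ug/mL.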

Compound 4, half-maximal inhibitory concentration: > 20 ug/mL
Compound 4 was reported as a limit; the forecaster's own chance of this, stated with the estimate: 70%; the middle value lies beyond the limit too.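

Among the compounds shown here, no step from compound 2 to compound 4 can be read, as compound 2 has no single number. Compound 4 gives > 20 ug/mL, which is a limit and not a number. The compounds shown leave open whether going from 2,4-dichlorophenyl to 4-chlorophenyl changes the result in this assay.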